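The source may report more compounds than this note shows. Statements on the series, on what has been measured and on what is new or still open speak of the compounds shown alone.

Compound 2 `CCN(CC)c1nc(Nc2cccc(C(=O)O)c2)nc(OCC(F)(F)C(F)F)n1` and compound 1 `CCN(CC)c1nc(Nc2cccc(C(=O)O)c2)nc(OC(C(F)(F)F)C(F)(F)F)n1` share one core and differ only in the group attached to the ring oxygen. Going by the values given here, in an assay on cells for activation of Cystic fibrosis transmembrane conductance regulator (Homo sapiens), read by fluorescence, with stated times of 10 min and 12 s (a higher number here means that more compound is needed for the effect, a lower number that less compound is needed), compound 1 gives 160 nM, while compound 2 gives 500 nM, the higher of the two numbers measured so far; this step is a 3.1-fold higher number from compound 1 to compound 2 (0.49 log units; beyond the scatter). Compound 3 `CCN(CC)c1nc(Nc2ccc(F)cc2)nc(OCC(F)(F)C(F)F)n1` has not yet been measured. It differs from compound 2 at a different place: 4-fluorophenyl in place of 3-carboxyphenyl on a nitrogen on an aromatic ring. Among the compounds with values here, no measured step touches this part of the molecule, since the one step known concerns only the group on the oxygen and says nothing about the ring on the nitrogen. The direction of the change is therefore open, and any estimate must carry a wide range. The number for compound 3 is expected to be about 1000 nM, somewhere between 200 nM and 6000 nM. That would be an expected step of a 2.0-fold higher number from compound 2 to compound 3 (0.30 log units; within the scatter).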

Compound 3, half-maximal effective concentration: 4800 nM
Beside the measured number, compound 3's estimate is 4.8-fold (0.68 log units) below it; measured number inside the range.
By their numbers in this assay, from the lowest: compound 1; then compound 2; then compound 3.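

Going by these compounds alone, this is the first measured change to the ring on the nitrogen: in this assay, 4-fluorophenyl in place of 3-carboxyphenyl gives a 9.6-fold higher number from compound 2 to compound 3 (0.98 log units; beyond the scatter) and lies beyond the scatter. The earlier change on the oxygen gave a 3.1-fold higher number from compound 1 to compound 2 (0.49 log units; beyond the scatter) and was smaller, so among these compounds the group on the nitrogen moves the number further than the group on the oxygen. No measurement shown here explains why this swap raises the number.

As far as these compounds go, the swap removes the carboxylic acid and adds a fluorine in a single move, so the share of each in the step stays open. Also open, from the compounds shown here alone, is how a ring carrying an amide or an amine would compare, and whether the step would be the same size with 2,2,2-trifluoro-1-(trifluoromethyl)ethyl on the oxygen.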